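Thiazolidinone series: para substituent swap on the benzylidene ring

The source may report more compounds than this note shows. Statements on the series, on what has been measured and on what is new or still open speak of the compounds shown alone.

Working notes on a small set of arylidene thiazolidinones tested for growth inhibition of a breast cancer line. Compound 1 `O=C1N/C(=N/c2csc(-c3ccc(Cl)cc3)c2)S/C1=C\c1ccc(O)cc1` and compound 2 `COc1cccc(N2C(=O)CS/C2=N\c2csc(C3CC=Cc4ccccc43)c2C2CC=Cc3ccccc32)c1` belong to the set, but in a functional assay on MDA-MB-231 cells (Homo sapiens) for cytotoxicity, read by MTT assay, with a stated time of 72 h (on this read-out lower numbers stand for stronger inhibition and higher numbers for weaker inhibition), compound 1 returns "not determined" (no result reported) and compound 2 likewise returns "not determined" (no result reported), so neither contributes a number. Compound 3 `CN(C)c1ccc(/C=C2\S/C(=N\c3nc(-c4ccc(Cl)cc4)cs3)NC2=O)cc1` is therefore the only member with a result: in this assay compound 3 gives 300 nM, and it stands alone on the numbers shown, with no measured neighbour against which a step could be sized.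

Compound 4 `COc1ccc(/C=C2\S/C(=N\c3nc(-c4ccc(Cl)cc4)cs3)NC2=O)cc1` is the next entry awaiting measurement. Among the compounds with values here, its single difference from compound 3 is methoxy in place of dimethylamino on an aromatic carbon, the rest of the molecule unchanged. Within the data shown here, no measured pair in the set reports the size of such a swap, so the expectation rests on compound 3 alone. A step of modest size toward weaker inhibition is expected, probably not far beyond the usual scatter, so the estimated step is a 2.0-fold higher number from compound 3 to compound 4 (0.30 log units; within the scatter). On that basis compound 4 is estimated to give 600 nM in this assay, within a range from 200 nM to 2000 nM.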

Compound 4, half-maximal inhibitory concentration: 300 nM
Beside the measured number, compound 4's estimate is 2.0-fold (0.30 log units) above it, within the range that was stated.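

This position now has its first sized step: in this assay, methoxy in place of dimethylamino on an aromatic carbon gives no change at the digits printed from compound 3 to compound 4 (within the scatter) and so leaves the read-out where it stood. For this one pair, the change from 4-(dimethylamino)phenyl to 4-methoxyphenyl, with the same counts of hydrogen-bond donors and acceptors on both sides, is not separated by the measurement, and the finding extends no further than compound 3 and compound 4. No measured property of either group is available to account for this result.

Within the data shown here, whether a carboxylic acid, a primary amine or a longer chain such as butoxy at this position would move the number beyond the usual scatter remains open, since the two groups compared here are the only ones with values at this site. Also open, as far as these compounds go, is whether the same swap would read alike with the rest of the molecule changed, as a single pair on a single core cannot settle that.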